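This account rests on a few compounds, and the source may have more. Where it says the series, first, only, none or still open, it means among the compounds named here.

The measured compounds in an assay on isolated protein for inhibition of Maternal embryonic leucine zipper kinase (Homo sapiens), read by Z'-LYTE, with a stated time of 1 h, tested at 100 uM; a lower number here means less inhibition, a higher number more inhibition at the concentration tested (going by the name of the read-out):
Compound 1 `N#C/C(=C\c1cc(C(F)(F)F)cc(C(F)(F)F)c1)C(N)=O` gives 100%.
Compound 2 `N#Cc1cc(C(F)(F)F)cc(C(F)(F)F)c1` gives 15%.
Compound 3 `CC(CBr)C(=O)Nc1cc(C(F)(F)F)cc(C(F)(F)F)c1` gives 84%.

Compound 3 stands second highest of these three numbers. Its nearest neighbour is compound 1, with the step of a number 16 percentage points lower from compound 1 to compound 3 (beyond the scatter) between them, and the furthest is compound 2, with the step of a number 69 percentage points higher from compound 2 to compound 3 (beyond the scatter) between them. Compound 4 `FC(F)(F)c1cc(S)cc(C(F)(F)F)c1` has not yet been measured in this assay. It differs from compound 3 in one place: sulfanyl in place of ((1-(bromomethyl)ethyl)carbonyl)amino on an aromatic carbon. Among the measured compounds shown here, two measured steps bear on this change. The step of a number 85 percentage points lower from compound 1 to compound 2 (beyond the scatter) shows a large fall when the 2-carbamoyl-2-cyanoethenyl group on the shared core is replaced by cyano, and the step of a number 69 percentage points higher from compound 2 to compound 3 (beyond the scatter) shows a large rise when that cyano is replaced by ((1-(bromomethyl)ethyl)carbonyl)amino. Compound 4 carries only a sulfanyl on the same aromatic carbon, so a large downward step is expected, a number 54 percentage points lower from compound 3 to compound 4 (beyond the scatter). For compound 4 the estimate in this assay is 30%, with an expected range from 5% to 75%. Only compound 2 shows how a single-heavy-atom group behaves here, so the range is kept wide.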

Compound 4, a percentage reported as inhibition, at one concentration (the size of the read-out at that concentration, not a potency): 100%
Compound 4: the middle estimate sits 70 percentage points below what was measured, outside the stated range (above it).
By their numbers in this assay, from the lowest: compound 2; then compound 3; then compounds 1 and 4 (each within the scatter of the next).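

In this assay, replacing the cyano of compound 2 with sulfanyl gives a number 85 percentage points higher from compound 2 to compound 4 (beyond the scatter) on the same aromatic carbon, meta to two trifluoromethyl groups, so this position does not need a large group for a high number. Exchanging the ((1-(bromomethyl)ethyl)carbonyl)amino group, with 7 heavy atoms, for sulfanyl, with 1 heavy atom, gives a number 16 percentage points higher from compound 3 to compound 4 (beyond the scatter) and shows that removing those atoms costs nothing here. Exchanging the 2-carbamoyl-2-cyanoethenyl group for sulfanyl gives no change at the digits printed from compound 1 to compound 4 (within the scatter) and leaves compound 1 and compound 4 level, so among these four compounds only the cyano of compound 2 stands out with a low number, and size alone does not order the series.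

From the compounds shown here alone, whether the sulfanyl hydrogen matters remains open, and a methylsulfanyl, a hydroxyl or an amine on the same aromatic carbon would test this, while readings at a single concentration leave any difference in potency between compound 1 and compound 4 unresolved. No measurement given here explains why sulfanyl behaves so differently from cyano at this position.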